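Replacing a Side Group: Expected Clearance of Compound 3

A few compounds are considered here, and "the series" means these few. Any claim that something is new, unique, unknown or untested is made for them only; others in the source may bear on it.

- compound 1 `COC(=O)C1=C(C)NC(c2nccs2)=NC1(C)c1ccc(S(C)(=O)=O)cc1` with 57 mL/min/kg
- compound 2 `COC(=O)C1=C(CN2CCC(F)(F)CC2)NC(c2nccs2)=NC1(C)c1ccc(F)cc1` with 88 mL/min/kg

In an ADME assay on microsomes from liver (Mus musculus) for metabolic stability, read by LC-MS, using NADPH, with stated times of 10 min and 30 min, tested at 1 uM (a higher number here means faster removal of the compound, a lower number slower removal), compound 2 (88 mL/min/kg) and compound 1 (57 mL/min/kg) lie within the usual scatter of each other, so neither clearly stands apart. Compound 3 `COC(=O)C1=C(COCC(F)(F)F)NC(c2nccs2)=NC1(C)c1ccc(F)cc1` differs from compound 2 (2,2,2-trifluoroethoxy in place of 4,4-difluoropiperidin-1-yl on a saturated chain carbon bound to a double-bonded ring carbon) by having 2,2,2-trifluoroethoxy in place of 4,4-difluoropiperidin-1-yl on a saturated chain carbon bound to a double-bonded ring carbon. Within the data shown here, no measured pair shows this change, so the expectation starts from compound 2 (88 mL/min/kg) alone. A small downward step, within the scatter, is expected (a 1.3-fold lower number from compound 2 to compound 3 (0.10 log units; within the scatter)). For compound 3 the estimated clearance is 70 mL/min/kg (range 40 mL/min/kg to 110 mL/min/kg).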

Compound 3, clearance: 81 mL/min/kg
Compound 3: the middle estimate sits 1.2-fold (0.06 log units) below what was measured; low and high end bracket the measured number.
By their numbers in this assay, from the lowest: compounds 1, 3 and 2 (each within the scatter of the next).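

Among these compounds, replacing the ring with the open chain gives a 1.1-fold lower number from compound 2 to compound 3 (0.04 log units; within the scatter) in this assay, the first comparison here that changes only this position. On a saturated chain carbon bound to a double-bonded ring carbon, 4,4-difluoropiperidin-1-yl and 2,2,2-trifluoroethoxy therefore cannot be told apart by clearance, so keeping the ring is not shown to matter in this pair. From the compounds shown here alone, whether a carboxylic acid or a morpholine ring at this position would give a clearly different number remains open. No supporting measurement is available to explain the result.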